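The source may report more compounds than this note shows. Statements on the series, on what has been measured and on what is new or still open speak of the compounds shown alone.

Measured so far in a functional assay on L1210 cells (Mus musculus) for inhibition; on this read-out lower numbers stand for stronger inhibition and higher numbers for weaker inhibition:
- compound 1 `C=C1[C@H](n2cnc3c(N)nc(N)nc32)O[C@H](CO)[C@H]1O`: 8200 nM
- compound 2 `C=C1[C@H](n2cnc3c(N(C)C)nc(N)nc32)O[C@H](CO)[C@H]1O`: 454000 nM

Compound 2 holds the higher of the two numbers and is the weaker inhibitor of the pair. For the measured compounds named here, the only measured step is a 55-fold higher number from compound 1 to compound 2 (1.74 log units; beyond the scatter), with dimethylamino in place of amino on an aromatic carbon.

Next is compound 3 `C=C1[C@H](n2cnc3c(OC)nc(N)nc32)O[C@H](CO)[C@H]1O`, still to be measured in this assay. It differs from compound 2 by methoxy in place of dimethylamino on an aromatic carbon.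

Going by the values given here, one measured step bears on this change, and only indirectly. a 55-fold higher number from compound 1 to compound 2 (1.74 log units; beyond the scatter) shows that replacing the group at this place can produce a large change, but no measured compound carries methoxy, so the evidence on its effect is thin. A moderate step toward lower numbers is expected, stopping short of the value of compound 1, and the range stays wide. The expected change is a 7.6-fold lower number from compound 2 to compound 3 (0.88 log units; beyond the scatter). Compound 3 is estimated at 60000 nM, with an expected range of 12000 nM to 300000 nM.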

Compound 3, half-maximal inhibitory concentration: 10000 nM
Compound 3: middle estimate off by 6.0-fold (0.78 log units), on the high side; measured number outside the range, below it.
By their numbers in this assay, from the lowest: compounds 1 and 3 (each within the scatter of the next); then compound 2.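

In this assay, the large step (a 45-fold lower number from compound 2 to compound 3 (1.66 log units; beyond the scatter)) shows that the loss seen on going to dimethylamino (a 55-fold higher number from compound 1 to compound 2 (1.74 log units; beyond the scatter)) does not follow from every replacement of amino on this aromatic carbon. Methoxy and amino cannot be told apart here (a 1.2-fold higher number from compound 1 to compound 3 (0.09 log units; within the scatter)), so within these three compounds only dimethylamino stands apart, and a change at this place can leave the number within the scatter. Methoxy and dimethylamino both count 0 hydrogen-bond donors and 1 hydrogen-bond acceptor, so these counts do not separate them, and nothing available gives a reason for the gap between them.

Open, from the compounds shown here alone, is where methylamino, with a single methyl on the nitrogen, would fall: with compound 1 and compound 3, with compound 2, or between them. Open as well is whether ethoxy, a longer chain on the oxygen, or a chlorine atom on this carbon would stay with compound 3, and so how far the tolerance seen for methoxy extends.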